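The compounds below may be only part of what the source reports. "The series", "measured", "known", "first", "only" and "open" are said of these compounds alone.

Measured compounds:
Compound 1 `Cc1c(-c2cc(Cl)cc(Cl)c2)c(C(=O)O)nn1-c1nc(-c2ccncc2)c(SC(C)C)s1`: "not active" (no number reported)
Compound 2 `COc1ccccc1-c1c(C)nn(-c2nc(-c3ccc(Cl)c(Cl)c3)c(SC(C)C)s2)c1C(=O)O`: 14700 nM

In a functional assay on BJAB cells (Homo sapiens) for antiproliferative activity, with a stated time of 4 days (on this read-out lower numbers stand for an effect already at smaller amounts and higher numbers for an effect only at larger amounts of compound), compound 2 gives 14700 nM. Compound 1 is reported in this assay as "not active" (no number reported) and carries no number. Among the measured compounds shown here, compound 2 thus stands as the only compound on this read-out with a number of its own; the one other entry offers nothing to set beside it. Compound 3 `Cc1nn(-c2nc(-c3ccc(Cl)c(Cl)c3)c(SC(C)C)s2)c(C(=O)O)c1-c1ccccc1` differs from compound 2 in a single place: hydrogen in place of methoxy on an aromatic carbon. For the measured compounds named here, no step between two measured compounds covers a change of this kind, so the expected size rests on the one number and on the change alone. Compound 3 is expected to come out near compound 2 or shifted toward larger amounts, the step of a 1.5-fold higher number from compound 2 to compound 3 (0.18 log units; within the scatter) being small and not clearly beyond the scatter. Compound 3 is estimated at 22000 nM, within 7000 nM to 70000 nM.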

Compound 3, half-maximal effective concentration: 3000 nM
Compound 3: middle estimate off by 7.3-fold (0.87 log units), on the high side; the whole stated range lies above it.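

Going from the 2-methoxyphenyl to the phenyl in this assay gives a 4.9-fold lower number from compound 2 to compound 3 (0.69 log units; beyond the scatter). Among the compounds shown here, this is the first reading at this position, on an aromatic carbon ortho to a large group, and it shows that the position responds to what it carries. Within this pair, methoxy is not needed for the effect, and the compound with hydrogen there acts at smaller amounts. Nothing given here accounts for the size of this step.

The pair cannot tell whether the gain belongs to hydrogen itself or whether another group, such as fluorine, hydroxyl or ethoxy, would do as well or better on the same carbon. It also leaves open whether the step would hold on a different core, since compound 1 differs in more than one place and has no number to compare.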